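The source may report more compounds than this note shows. Statements on the series, on what has been measured and on what is new or still open speak of the compounds shown alone.

Compound 1 `O=C(C(c1ccccc1)c1ccccc1)N1CCN(CCCn2c(=O)[nH]c3ccccc32)CC1`: 7800 nM
Compound 2 `Cc1nc2ccccc2n1CCCCN1CCN(C(c2ccccc2)c2ccccc2)CC1`: 850 nM
Compound 3 `c1ccc(-c2nc3ccccc3n2CCCCN2CCN(C(c3ccccc3)c3ccccc3)CC2)cc1`: 1200 nM

In an assay on RPMI-8226 cells for antagonist activity at P2X purinoceptor 7 (Homo sapiens), read by calcium flux (on this read-out lower numbers stand for stronger inhibition and higher numbers for weaker inhibition), compound 2 gives the lowest of these three numbers; compound 3 sits within the scatter of it, while compound 1 lies well beyond. Compound 4 `c1ccc(-c2nnnn2CCCCN2CCN(C(c3ccccc3)c3ccccc3)CC2)cc1` differs from compound 2 in one place: 5-phenyl-1H-tetrazol-1-yl in place of 2-methyl-1H-benzimidazol-1-yl on a saturated chain carbon, four bonds along the chain from an amine nitrogen in a ring. Within the data shown here, only one measured step touches this part of the molecule, a 1.4-fold higher number from compound 2 to compound 3 (0.15 log units; within the scatter), which also brings in a phenyl but keeps the ring system. Among the measured compounds shown here, no measured pair exchanges the five-membered aromatic ring with 2 hetero atoms for one with 4 hetero atoms, so that part of the change has no precedent here. The expected outcome is therefore a step of about the scatter in this assay, estimated as a 1.8-fold higher number from compound 2 to compound 4 (0.25 log units; within the scatter). For compound 4 the estimate is 1500 nM, with a range from 400 nM to 6000 nM.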

Compound 4, half-maximal inhibitory concentration: 3200 nM
Compound 4: middle estimate off by 2.1-fold (0.33 log units), on the low side, within the range that was stated.
By their numbers in this assay, from the lowest: compounds 2 and 3 (each within the scatter of the next); then compound 4; then compound 1.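

In this assay, the group on this saturated chain carbon does matter: a 3.8-fold higher number from compound 2 to compound 4 (0.58 log units; beyond the scatter) lies beyond the scatter, whereas a 1.4-fold higher number from compound 2 to compound 3 (0.15 log units; within the scatter) stayed within it. This replacement therefore weakens inhibition measurably, although the new group has the same number of hydrogen-bond donors and no net charge. Nothing measured here explains this loss. The compounds shown leave open whether the five-membered aromatic ring with 4 hetero atoms alone accounts for the step, and whether 5-methyl-1H-tetrazol-1-yl or a longer chain would recover inhibition.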